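This account rests on a few compounds, and the source may have more. Where it says the series, first, only, none or still open, it means among the compounds named here.

Compound 1 `COc1ccc(N(C)c2ncnc3c2ncn3Cc2ccc(OC)c(OC)c2)cc1` and compound 2 `COc1ccc(N(C)c2ncnc3c2ncn3Cc2cc(OC)cc(OC)c2)cc1` share a common framework and are built from the same atoms, joined differently; the difference between them is 3,5-dimethoxyphenyl in place of 3,4-dimethoxyphenyl on a saturated chain carbon bound to an aromatic nitrogen. Compound 3 `COc1ccc(Cn2cnc3c(Cl)ncnc32)cc1OC` keeps the core of compound 1 but carries a chloro in place of the (4-methoxyphenyl)(methyl)amino group, as described by chloro in place of (4-methoxyphenyl)(methyl)amino on an aromatic carbon. Compound 4 `COc1cc(Cn2cnc3c(Cl)ncnc32)cc(OC)c1` is built from compound 2 by the same exchange, (chloro in place of (4-methoxyphenyl)(methyl)amino on an aromatic carbon), and has not yet been measured.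

In a functional assay on AGS cells (Homo sapiens) for antiproliferative activity, read by MTT assay, with a stated time of 48 h (on this read-out lower numbers stand for stronger inhibition of growth and higher numbers for weaker inhibition of growth), compound 1 gives > 100000 nM, which is a limit of the assay and not a number. In this assay compound 2 gives > 100000 nM, again a limit rather than a number. In this assay compound 3 gives > 100000 nM, also a limit. Because of this, (the limit of > 100000 nM in this assay, at which 3 of the 3 values shown sit), the two measured steps are a step that the two limits leave unreadable from compound 1 to compound 2 and a step that the two limits leave unreadable from compound 1 to compound 3.

For compound 4 the expected step in this assay is a step that the limit leaves unreadable from compound 2 to compound 4, resting on the unreadable step from compound 1 to compound 3 and on compound 2 sitting at > 100000 nM. Compound 4 is therefore expected to give 150000 nM in this assay, most likely again reported only as a limit.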

Compound 4, concentration for 50% growth inhibition: > 100000 nM
Compound 4 was reported as a limit; the forecaster's own chance of this, stated with the estimate: 85%; the middle value is on the limit's open side.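

No new step can be read between compound 2 and compound 4. In this assay compound 4 gives > 100000 nM, which is a limit and not a number. The whole set stops at the same point: the limit of > 100000 nM in this assay, at which 4 of the 4 values shown sit. The compounds shown leave open how strongly any of them inhibits growth, and whether exchanging (4-methoxyphenyl)(methyl)amino for chloro changes that at all.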